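Capping a phenol: compound 2 to compound 3

The source may report more compounds than this note shows. Statements on the series, on what has been measured and on what is new or still open speak of the compounds shown alone.

Compound 1 `O=C(Nc1cccc(-n2cc(-c3ccncc3)c(-c3cc(O)cc(Cl)c3)n2)c1)Nc1ccc(Cl)c(C(F)(F)F)c1` and compound 2 `O=C(Nc1cccc(-n2cc(-c3ccncc3)c(-c3cc(O)cc(Cl)c3)n2)c1)Nc1ccc(Cl)c(Cl)c1` share one core. In a functional assay on UACC-62 cells (Homo sapiens) for inhibition, read by sulforhodamine B assay, with a stated time of 48 h, tested at 10 uM (on this read-out higher numbers stand for a weaker effect at the one concentration tested and lower numbers for a stronger effect), compound 1 gives -1.44%, while compound 2 gives -61.8%, the lowest of the two numbers; the change was a number 60.4 percentage points lower from compound 1 to compound 2 (beyond the scatter). Compound 3 `COc1cc(Cl)cc(-c2nn(-c3cccc(NC(=O)Nc4ccc(Cl)c(Cl)c4)c3)cc2-c2ccncc2)c1` differs from compound 2 by methyl in place of hydrogen on an oxygen on an aromatic ring. Among the compounds with values here, no measured step touches the hydroxy group, so the earlier step gives no guide here, and only a modest, uncertain shift is expected, written as a number 16.8 percentage points higher from compound 2 to compound 3 (beyond the scatter). Compound 3 is therefore estimated at -45%, within -85% to 0%.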

Compound 3, a percentage reported as activity, at one concentration (the size of the read-out at that concentration, not a potency): 4.38%
The estimate for compound 3 lay 49.4 percentage points below the measured number, and the stated range ends below it.
By their numbers in this assay, from the lowest: compound 2; then compounds 1 and 3 (each within the scatter of the next).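

In this assay the hydroxy to methoxy change gives a number 66.2 percentage points higher from compound 2 to compound 3 (beyond the scatter), so adding a single methyl on this oxygen removes most of the effect seen with compound 2. This shows that the hydroxy group is a sensitive position, which the earlier step could not reveal, as it changed a different place in the molecule. No measurement available here explains this loss.

Still open, on these data alone, is whether an amine in place of the hydroxy group would retain the effect, or whether a longer chain such as ethoxy on this oxygen would weaken it as methoxy does.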